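The source may report more compounds than this note shows. Statements on the series, on what has been measured and on what is new or still open speak of the compounds shown alone.

Among the measured compounds shown here, compound 2 `COc1ccc(Nc2nc3ccccc3nc2S(=O)(=O)c2ccccc2)cc1` gives 1510 nM in a functional assay on PC-3 cells (Homo sapiens) for cytotoxicity, read by MTT assay, with a stated time of 72 h (a lower number here means a stronger inhibitor, a higher number a weaker inhibitor), the higher of the two numbers so far; compound 1 `O=S(=O)(c1ccccc1)c1nc2ccccc2nc1Nc1ccccc1` gives 590 nM in this assay. Compound 3 `COc1cc(Nc2nc3ccccc3nc2S(=O)(=O)c2ccccc2)cc(OC)c1` carries 3,5-dimethoxyphenyl in place of 4-methoxyphenyl on a nitrogen on an aromatic ring. For the measured compounds named here, the only measured step that bears on this, a 2.6-fold higher number from compound 1 to compound 2 (0.41 log units; beyond the scatter), shows that a methoxy on the aromatic ring moved the number up modestly. A further shift toward more methoxy groups is therefore expected to give at most a small rise, a 1.3-fold higher number from compound 2 to compound 3 (0.12 log units; within the scatter), possibly within the scatter. Compound 3 is estimated at 2000 nM in this assay, with a range from 700 nM to 6000 nM.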

Compound 3, half-maximal inhibitory concentration: 140 nM
The estimate for compound 3 lay 14-fold (1.15 log units) above the measured number, outside the stated range (below it).
By their numbers in this assay, from the lowest: compound 3; then compound 1; then compound 2.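

In this assay the methoxy groups on this aryl group do not all push the number the same way: the change to 3,5-dimethoxyphenyl gives an 11-fold lower number from compound 2 to compound 3 (1.03 log units; beyond the scatter) and also takes the series past the unsubstituted phenyl with a 4.2-fold lower number from compound 1 to compound 3 (0.62 log units; beyond the scatter). The rise seen with 4-methoxyphenyl therefore does not hold for every methoxy pattern on a nitrogen on an aromatic ring. Nothing available explains this reversal. The compounds shown leave open whether the lower number needs both methoxy groups, and how an amine, a carboxylic acid or a longer chain would behave on this ring.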